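A few compounds are considered here, and "the series" means these few. Any claim that something is new, unique, unknown or untested is made for them only; others in the source may bear on it.

Measured compounds:
Compound 1 `C=C1[C@@H](OC(C)=O)C[C@@H]2[C@](C)(CO[Si](C)(C)C(C)(C)C)[C@H](OC(C)=O)CC[C@@]2(C)[C@@H]1C[C@@H](Nc1ccc(OC)cc1)C1=CCOC1=O`: 4280 nM
Compound 2 `C=C1[C@@H](OC(C)=O)C[C@@H]2[C@](C)(COC=O)[C@H](OC(C)=O)CC[C@@]2(C)[C@@H]1C[C@@H](Nc1ccccc1C(=O)O)C1=CCOC1=O`: 30800 nM

Both were tested in a functional assay on MCF7 cells (Homo sapiens) for cytotoxicity, read by sulforhodamine B assay; a higher number here means a weaker inhibitor, a lower number a stronger inhibitor. Compound 1 gives 4280 nM, and compound 2 gives 30800 nM. Of these two numbers, compound 2 holds the higher one, and its gap to compound 1 lies beyond the usual scatter, so compound 2 is the weaker inhibitor of the pair. The two compounds differ at more than one place, so their values alone cannot be traced to any single structural step.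

Compound 3 `C=C1[C@@H](OC(C)=O)C[C@@H]2[C@](C)(COC=O)[C@H](OC(C)=O)CC[C@@]2(C)[C@@H]1C[C@@H](Nc1ccccc1)C1=CCOC1=O` has not yet been measured. It differs from compound 2 in one place:

hydrogen in place of carboxy on an aromatic carbon

Everything else in the shared core, including the two acetate groups and the formate-bearing chain, is kept.

Going by the values given here, no measured pair shows this change by itself, so the direction has to be judged from the two values alone. Starting from compound 2 at 30800 nM, a modest move toward a lower number is expected, roughly at the edge of the scatter. The expected step is a 3.4-fold lower number from compound 2 to compound 3 (0.53 log units; beyond the scatter). In this assay compound 3 is estimated to give 9000 nM, with a range from 2500 nM to 30000 nM.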

Compound 3, half-maximal inhibitory concentration: 26200 nM
Compound 3: middle estimate off by 2.9-fold (0.46 log units), on the low side; the range from low to high includes it.
By their numbers in this assay, from the lowest: compound 1; then compounds 3 and 2 (each within the scatter of the next).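

In this assay, replacing the carboxy group on the aromatic carbon with hydrogen, which turns (2-carboxyphenyl)amino into anilino, gives a 1.2-fold lower number from compound 2 to compound 3 (0.07 log units; within the scatter). Going by these compounds alone, this is the first comparison in the set that isolates a single change, and it shows that, at this place on the six-membered aromatic ring, ortho to a large group, the read-out does not separate carboxy from hydrogen, even though three heavy atoms leave, along with a hydrogen-bond donor and a hydrogen-bond acceptor. No supporting measurement offers an explanation for this result.

On these data alone, the step covers only these two groups at this one aromatic carbon, on a core that keeps its formate-bearing chain and two acetate groups, so it remains open whether a nitrile or an amide at the same carbon would also leave the number within the scatter. As far as these compounds go, it is also open whether carboxy would matter on a different carbon of the ring, or with a different group in place of the formate-bearing chain, as no single-change comparison here tests either question.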